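A Hydroxy for a Methyl at the Detection Limit

The source may report more compounds than this note shows. Statements on the series, on what has been measured and on what is new or still open speak of the compounds shown alone.

Compound 2 `Cc1ccc(-c2ccccc2OC(C)C2=NCCN2)cc1` carries a methyl on its outer ring. In a functional assay on CHO cells for agonist activity at Alpha-2B adrenergic receptor (Homo sapiens) (on this read-out lower numbers stand for smaller maximal responses and higher numbers for larger maximal responses), compound 2 gives < 0.3, which is a limit of the assay rather than a number. Compound 1 `CC(Oc1ccccc1-c1ccc([N+](=O)[O-])cc1)C1=NCCN1` also reaches only a limit in this assay, namely < 0.3. Compound 3 `Cc1ccccc1-c1ccccc1OC(C)C1=NCCN1` likewise gives a limit in this assay, < 0.3. Both a step that the two limits leave unreadable from compound 1 to compound 2 and a step that the two limits leave unreadable from compound 2 to compound 3 stay hidden because of the limit of < 0.3 in this assay, at which 3 of the 3 values shown sit. Compound 4 `CC(Oc1ccccc1-c1ccc(O)cc1)C1=NCCN1` differs from compound 2 by hydroxy in place of methyl on an aromatic carbon. Among the measured compounds shown here, no measured step touches this change, and every neighbour sits at the limit, so compound 4 is expected to remain there, with a step that the limit leaves unreadable from compound 2 to compound 4 expected to lie within the scatter. Compound 4 is therefore estimated at 0.2, in a range from 0.05 to 0.4.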

Compound 4, intrinsic activity: the largest response reached, as a fraction of the reference agonist's: < 0.3
Compound 4: only a limit was reported; the forecaster's own chance of this, stated with the estimate: 70%; the middle value is on the limit's open side.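

Compound 4 sits at the same limit as compound 1, compound 2 and compound 3, so no step between these compounds can be read: the limit of < 0.3 in this assay, at which 4 of the 4 values shown sit.

The compounds shown leave open whether their true maximal responses differ at all.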